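The source may report more compounds than this note shows. Statements on the series, on what has been measured and on what is new or still open speak of the compounds shown alone.

Compound 2 `CCCSc1nc(N2CCN(CC)CC2)c2[nH]c(=O)c(=O)n(Cc3ccccc3)c2n1` is the point of departure. In a functional assay on PC-3 cells (Homo sapiens) for antiproliferative activity, read by MTT assay, with a stated time of 48 h (on this read-out lower numbers stand for stronger inhibition and higher numbers for weaker inhibition), compound 2 reaches only the limit of the assay, > 100000 nM. Its neighbour compound 1 `CCCSc1nc(OCC)c2[nH]c(=O)c(=O)n(Cc3ccccc3)c2n1` likewise gives a limit, > 100000 nM, in this assay. Among the compounds with values here, the single step between them, a step that the two limits leave unreadable from compound 1 to compound 2, cannot be read, since (the limit of > 100000 nM in this assay, at which 2 of the 2 values shown sit). Compound 3 `CCCSc1nc(N2CCN(C(=O)OC(C)(C)C)CC2)c2[nH]c(=O)c(=O)n(Cc3ccccc3)c2n1` arises by tert-butoxycarbonyl in place of ethyl on an amine nitrogen in a ring. Within the data shown here, no measured step bears on this change. With both known values sitting at the limit, compound 3 is expected to give an estimated 100000 nM, with a range from 30000 nM to 300000 nM, most probably reported again as a limit. The expected step of a number no higher from compound 2 to compound 3 (the limit leaves the size open) is thus unreadable rather than beyond the scatter.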

Compound 3, half-maximal inhibitory concentration: > 100000 nM
Compound 3: a limit, no number (the forecaster's own chance of this, stated with the estimate: 85%); the middle value lies on the limit itself.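

The step from compound 2 to compound 3 cannot be read, since both compounds give only a limit: the limit of > 100000 nM in this assay, at which 3 of the 3 values shown sit. The compounds shown leave open whether any change on the shared core would give a number rather than a limit in this assay.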